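The source may report more compounds than this note shows. Statements on the series, on what has been measured and on what is new or still open speak of the compounds shown alone.

Measured compounds:
compound 1 `O=C1Nc2ccccc2/C1=C\c1c(Cl)n(Cc2ccccc2)c2ccccc12`, 20400 nM in a functional assay on cells (Cancer cell lines, Homo sapiens) for cytotoxicity, with a stated time of 48 h; a lower number here means a stronger inhibitor of growth, a higher number a weaker inhibitor of growth
compound 2 `O=C1Nc2ccccc2/C1=C\c1c(Cl)n(CCCc2ccccc2)c2ccccc12`, 19100 nM
compound 3 `COc1c(/C=C2/C(=O)Nc3ccc(Cl)cc32)c2ccccc2n1-c1ccccc1`, 9330 nM

Among these three numbers for growth inhibition, compound 2 stands second highest; its nearest neighbour is compound 1, a 1.1-fold lower number from compound 1 to compound 2 (0.03 log units; within the scatter), a step within the scatter, while compound 3 lies furthest away with a lower number, a gap beyond the scatter.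

Compound 4 `O=C1Nc2ccc(Cl)cc2/C1=C\c1c(Cl)n(CCCc2ccccc2)c2ccccc12` has not yet been measured. It differs from compound 2 in one place: chloro in place of hydrogen on an aromatic carbon. Among the compounds with values here, no measured pair differs by this change alone; the only step recorded, from compound 1 to compound 2, concerns the chain on the nitrogen and is within the scatter, so it says nothing about a chloro on the ring. Compound 3 does carry a chloro at the corresponding position and gives 9330 nM, but it also differs from compound 2 elsewhere, so its value is only a loose pointer. A modest move toward a lower number, perhaps no further than the scatter, is therefore expected: a 1.6-fold lower number from compound 2 to compound 4 (0.20 log units; within the scatter). Compound 4 is estimated at 12000 nM, with a likely range from 5000 nM to 30000 nM.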

Compound 4, concentration for 50% growth inhibition: 2000 nM
For compound 4 the middle estimate is 6.0-fold (0.78 log units) above the measured one; the whole stated range lies above it.
By their numbers in this assay, from the lowest: compound 4; then compound 3; then compounds 2 and 1 (each within the scatter of the next).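

In this assay, chloro in place of hydrogen gives a 9.6-fold lower number from compound 2 to compound 4 (0.98 log units; beyond the scatter), a step beyond the scatter, whereas the change to the chain on the aromatic nitrogen, a 1.1-fold lower number from compound 1 to compound 2 (0.03 log units; within the scatter), stays within it. This shows that growth inhibition responds to a single added chlorine on this aromatic carbon, in a six-membered aromatic ring of carbon only that is part of a fused or bridged system of two rings. Nothing available accounts for the size of this step.

The compounds shown leave open whether fluoro, bromo, methoxy, an amine or a carboxylic acid on this same carbon would give a similar step. They also leave open whether chloro here would give a step of this size with the chain of compound 1 on the nitrogen.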